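A few compounds are considered here, and "the series" means these few. Any claim that something is new, unique, unknown or untested is made for them only; others in the source may bear on it.

Compound 1: `O=C(Nc1cccc([N+](=O)[O-])c1)Nc1nc2ccc(F)cc2s1`, 1.96 ug/mL
Compound 2: `COc1ccc2sc(NC(=O)c3ccc(C)cc3)nc2c1`, > 10 ug/mL
Compound 3: `Cc1cc(C)c2sc(NC(=O)c3ccc([N+](=O)[O-])cc3)nc2c1`, 1.74 ug/mL

All three compounds were tested in a functional assay on SK-HEP1 cells (Homo sapiens) for antiproliferative activity, read by sulforhodamine B assay; a higher number here means a weaker inhibitor of growth, a lower number a stronger inhibitor of growth. Compound 1 gives 1.96 ug/mL and compound 3 gives 1.74 ug/mL, two values that lie within the usual scatter of each other. For compound 2 the result is only a limit of the assay, > 10 ug/mL, so no number is known for compound 2; it sits at the limit of > 10 ug/mL in this assay, at which 1 of the 3 values shown sits.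

Compound 4, `COc1ccc2sc(NC(=O)c3ccc(C(F)(F)F)cc3)nc2c1`, has not yet been measured in this assay. It differs from compound 2 in one place: trifluoromethyl in place of methyl on an aromatic carbon. Going by the values given here, no measured pair shows this exchange, so its effect is unknown. Compound 3 carries a nitro group where compound 2 carries methyl and differs from it elsewhere too; in this assay compound 3 gives 1.74 ug/mL, which shows that a different group at this position can go with a measured number, though it says nothing directly about trifluoromethyl.

The expected step from compound 2 to compound 4 is an at least 1.6-fold lower number from compound 2 to compound 4 (0.22 log units; that floor lies within the scatter), toward stronger inhibition but with wide uncertainty. For compound 4 the estimate is 6 ug/mL, between 2 ug/mL and 15 ug/mL.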

Compound 4, concentration for 50% growth inhibition: > 10 ug/mL
Compound 4 ended at the assay's limit; the forecaster's own chance of this, stated with the estimate: 45%; middle value at least 1.6-fold (0.22 log units) from the limit.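

In this assay, compound 2 and compound 4 both end at a limit rather than a number, so no step between them can be read: the limit of > 10 ug/mL in this assay, at which 2 of the 4 values shown sit.

Still open, from the compounds shown here alone, is whether trifluoromethyl in place of methyl on an aromatic carbon changes growth inhibition at all, and in which direction.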